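A few compounds are considered here, and "the series" means these few. Any claim that something is new, unique, unknown or untested is made for them only; others in the source may bear on it.

Compound 3 `COc1cc2c(Oc3ccc(NC(=O)c4cc(-c5cccc(Cl)c5)nc5ccc(F)cc45)cc3F)ccnc2cc1OCCCN1CCC(C)CC1`: 92 nM
Compound 1 `COc1cc2c(Oc3ccc(NC(=O)c4cc(-c5cccc(Cl)c5)nc5ccccc45)cc3F)ccnc2cc1OCCCN1CCC(C)CC1`: 100 nM
Compound 2 `COc1cc2c(Oc3ccc(NC(=O)c4cc(-c5ccc(C)cc5)nc5ccc(F)cc45)cc3F)ccnc2cc1OCCCN1CCCCC1`: 500 nM

Among these three, compound 3 shows the lowest number in a functional assay on HT-29 cells (Homo sapiens) for cytotoxicity, read by MTT assay, with a stated time of 72 h (on this read-out lower numbers stand for stronger inhibition and higher numbers for weaker inhibition), though compound 1 sits within the scatter of it, while compound 2 stands beyond the scatter above both. Within the data shown here, the single measured step, a 1.1-fold lower number from compound 1 to compound 3 (0.04 log units; within the scatter), concerns the fluoro and not the change now in question. Compound 4 `COc1cc2c(Oc3ccc(NC(=O)c4cc(-c5ccc(C)cc5)nc5ccc(F)cc45)cc3F)ccnc2cc1OCCCN1CCC(C)CC1` carries 4-methylphenyl in place of 3-chlorophenyl on an aromatic carbon. Among the measured compounds shown here, no measured pair isolates this swap; the 4-methylphenyl is already borne by compound 2, which differs from compound 4 in one other place. In this assay compound 2 gives 500 nM. Compound 4 is therefore expected to shift by a 2.7-fold higher number from compound 3 to compound 4 (0.43 log units; beyond the scatter) toward a higher number. The estimate for compound 4 is 250 nM, with a range from 100 nM to 700 nM.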

Compound 4, half-maximal inhibitory concentration: 420 nM
Estimate against measurement, compound 4: 1.7-fold (0.23 log units) below; the measured number falls inside the stated range.
By their numbers in this assay, from the lowest: compounds 3 and 1 (each within the scatter of the next); then compounds 4 and 2 (each within the scatter of the next).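

In this assay, among these compounds, the group on the aromatic carbon next to the ring nitrogen proves to matter: 4-methylphenyl in place of 3-chlorophenyl gives a 4.6-fold higher number from compound 3 to compound 4 (0.66 log units; beyond the scatter), the first direct reading of this swap. The methyl on the saturated ring carbon, by contrast, gives only a 1.2-fold lower number from compound 2 to compound 4 (0.08 log units; within the scatter), so it does not account for the high number of compound 2. Nothing available here explains the step.

The swap alters both the substituent and its place on the phenyl ring, and the compounds shown do not separate the two. As far as these compounds go, how a plain phenyl or a pyridyl group would read at this carbon also stays open.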